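Stripping the ester chain down to a bare hydroxy

The compounds below may be only part of what the source reports. "The series", "measured", "known", "first", "only" and "open" are said of these compounds alone.

Of the compounds shown here, three have numbers so far. Compound 1 `CCCCSc1ccc2ccc(/C=C/c3cccc(OCC(=O)OC)c3)nc2c1` gives 1500 nM in a functional assay on lung (Cavia porcellus) for binding affinity to cysteinyl leukotriene receptor (Homo sapiens); on this read-out lower numbers stand for stronger inhibition and higher numbers for weaker inhibition. Compound 2 `O=C(O)CCCOc1cccc(/C=C/c2ccc3cc(Cl)ccc3n2)c1` gives 270 nM in this assay. Compound 3 `CCOC(=O)CCCOc1cccc(/C=C/c2ccc3ccccc3n2)c1` gives 580 nM in this assay. Among these three numbers compound 3 holds the second highest; its nearest neighbour is compound 2, whose number is lower by a margin beyond the scatter, while compound 1 sits furthest away with a higher number, again beyond the scatter.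

The next compound, compound 4 `Oc1cccc(/C=C/c2ccc3ccccc3n2)c1`, has not been measured. Set against compound 3 it differs in one place: hydrogen in place of 3-(ethoxycarbonyl)propyl on an oxygen on an aromatic ring. All three measured compounds carry either an acid or an ester on that aromatic oxygen, and nothing among them shows what a hydroxy alone does. For the measured compounds named here, no measured pair has this change, so the expectation leans on the fact that every compound with a number here keeps such a chain, and on compound 3 itself with its 580 nM.

The step from compound 3 to compound 4 is expected to run toward a higher number, beyond the scatter, at a 5.2-fold higher number from compound 3 to compound 4 (0.71 log units; beyond the scatter). For compound 4 the estimate is 3000 nM, with a range from 800 nM to 12000 nM.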

Compound 4, half-maximal inhibitory concentration: 560 nM
Estimate against measurement, compound 4: 5.4-fold (0.73 log units) above; the measured number lies below the stated range.
By their numbers in this assay, from the lowest: compound 2; then compounds 4 and 3 (each within the scatter of the next); then compound 1.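

In this assay the exchange of 3-(ethoxycarbonyl)propyl for hydrogen on the oxygen on an aromatic ring gives a 1.0-fold lower number from compound 3 to compound 4 (0.02 log units; within the scatter) and so puts the two compounds level. For the compounds shown here, this is the first read on the position without any chain: across this one pair, the 3-(ethoxycarbonyl)propoxy group, with its 8 heavy atoms and its ester carbonyl, can be cut back to a hydroxy without a difference that the assay can separate from scatter, so on the shared core the ester chain adds nothing measurable over the bare hydroxy. No measured evidence on the compounds here speaks to why the two numbers sit together.

The compounds shown leave open whether a carboxylic acid at the end of the same chain would behave like the ethyl ester or the hydroxy on the core of compound 4, since the one acid here also differs from that core by a chlorine. They also leave open what a simple methoxy, a shorter or longer chain, or an amine at the end of the chain would do on this oxygen.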